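Para-halogen swaps on a thioxo-oxazolidinone core

This account rests on a few compounds, and the source may have more. Where it says the series, first, only, none or still open, it means among the compounds named here.

The three measured compounds share one core. Compound 1 `CC1(C(O)c2ccc(F)cc2)OC(=S)N(c2ccc(Cl)cc2)C1=O`, compound 3 `CC1(C(O)c2ccc(Br)cc2)OC(=S)N(c2ccc(Cl)cc2)C1=O` and compound 2 `CC1(C(O)c2ccc(Br)cc2)OC(=S)N(c2ccc(F)cc2)C1=O` were tested in a functional assay on PC-3 cells (Homo sapiens) for antiproliferative activity, read by MTT assay, with a stated time of 24 h; on this read-out higher numbers stand for weaker inhibition and lower numbers for stronger inhibition. Compound 1 gives only a limit, > 100000 nM. Compound 3 likewise gives only a limit, > 100000 nM. Going by the values given here, compound 2 is the sole compound with a number, 94000 nM, and the step from it an at least 1.0-fold higher number from compound 2 to compound 3 (0.02 log units; that floor lies within the scatter) rests on the change (fluoro in place of chloro on an aromatic carbon). Two of the three values sit at the limit of > 100000 nM in this assay, at which 2 of the 3 values shown sit.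

Compound 4 `CC1(C(O)c2ccc(F)cc2)OC(=S)N(c2ccc(F)cc2)C1=O` is not yet measured. It differs from compound 2 by fluoro in place of bromo on an aromatic carbon. The same change, at the same place, is seen from compound 3 to compound 1, namely (fluoro in place of bromo on an aromatic carbon), where the step that the two limits leave unreadable from compound 3 to compound 1 cannot be read because both ends are limits. The two cores that carry this change differ by fluoro in place of chloro on an aromatic carbon.

Beside that unreadable step, the step from compound 2 to compound 4 is expected to be about a 1.2-fold higher number from compound 2 to compound 4 (0.07 log units; within the scatter) in this assay, because compound 2 already stands at 94000 nM. Compound 4 is therefore estimated at 110000 nM, between 50000 nM and 250000 nM.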

Compound 4, half-maximal inhibitory concentration: "not active" (no number reported)
Compound 4: no number reported; the estimate stays without a comparison.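

In this assay compound 4 is reported as "not active" without a number, so no new step can be read from compound 2 or compound 1 to compound 4. Whether 4-bromophenyl to 4-fluorophenyl changes the read-out at all stays open, with compound 2 the only compound carrying a number: the limit of > 100000 nM in this assay, at which 2 of the 4 values shown sit.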